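Swapping the Trichlorophenylamino Group for a Dimethylaminomethylphenyl

A few compounds are considered here, and "the series" means these few. Any claim that something is new, unique, unknown or untested is made for them only; others in the source may bear on it.

Compound 2 `COc1cc(Nc2ncnc3c(NC(=O)Nc4cc(Cl)c(Cl)cc4Cl)cccc23)cc(OC)c1` gives 4890 nM in a functional assay on RT-112 cells (Homo sapiens) for antiproliferative activity, read by MTT assay, with a stated time of 72 h (a lower number here means a stronger inhibitor of growth, a higher number a weaker inhibitor of growth), the highest number among the three measured compounds. Compound 3 `COc1cc(Nc2ncnc3c(NC(=O)Nc4ccc(F)cc4C(F)(F)F)cccc23)cc(OC)c1` gives 2970 nM, and a 1.6-fold lower number from compound 2 to compound 3 (0.22 log units; within the scatter). Compound 1 `COc1cc(Nc2ncnc3c(NC(=O)Nc4cc(Cl)cc(Cl)c4)cccc23)cc(OC)c1` gives 30.2 nM; the steps of a 160-fold higher number from compound 1 to compound 2 (2.21 log units; beyond the scatter) and a 98-fold higher number from compound 1 to compound 3 (1.99 log units; beyond the scatter) show how strongly the group on the amide-type nitrogen can move the number. Compound 4 `COc1cc(Nc2ncnc3c(NC(=O)c4ccc(CN(C)C)cc4)cccc23)cc(OC)c1` carries 4-((dimethylamino)methyl)phenyl in place of (2,4,5-trichlorophenyl)amino on a carbonyl carbon. Within the data shown here, none of the measured steps changes the neighbour of the carbonyl carbon in this way, so they give no direction, only a sense of scale. Because a 160-fold higher number from compound 1 to compound 2 (2.21 log units; beyond the scatter) was large, a large step is expected in this assay, with a 9.8-fold lower number from compound 2 to compound 4 (0.99 log units; beyond the scatter) as the estimated step. Compound 4 is estimated at 500 nM, within a range from 50 nM to 5000 nM.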

Compound 4, concentration for 50% growth inhibition: 4370 nM
Estimate against measurement, compound 4: 8.7-fold (0.94 log units) below; the measured number falls inside the stated range.
By their numbers in this assay, from the lowest: compound 1; then compounds 3, 4 and 2 (each within the scatter of the next).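

Putting 4-((dimethylamino)methyl)phenyl on the carbonyl carbon leaves the number where it was, with a 1.1-fold lower number from compound 2 to compound 4 (0.05 log units; within the scatter) and a 1.5-fold higher number from compound 3 to compound 4 (0.17 log units; within the scatter) both inside the scatter. The third comparison, a 140-fold higher number from compound 1 to compound 4 (2.16 log units; beyond the scatter), shows that this new group does not reach the level set by the (3,5-dichlorophenyl)amino group, which stays alone at the low end of these four compounds. Nothing measured here explains this result.

Still open, from the compounds shown here alone, is whether a 3,5-dichlorophenyl group on the carbonyl carbon, without the amino nitrogen, would keep the low number. A carboxylic acid or a morpholine in place of the dimethylamino group is also untested among the compounds shown.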